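This account rests on a few compounds, and the source may have more. Where it says the series, first, only, none or still open, it means among the compounds named here.

Working notes on the series. The shared core is held constant across compound 1 `CN(C)C(=O)c1cc2cnc(Nc3ccc(NC(=O)C4(C(=O)Nc5ccc(Cl)c(C(F)(F)F)c5)CC4)cc3)nc2n1C1CCCC1`, compound 2 `CN(C)C(=O)c1cc2cnc(Nc3ccc(NC(=O)C4(C(=O)Nc5cccc(Br)c5)CC4)cc3)nc2n1C1CCCC1` and compound 3 `COC(=O)c1ccc(NC(=O)C2(C(=O)Nc3ccc(Nc4ncc5cc(C(=O)N(C)C)n(C6CCCC6)c5n4)cc3)CC2)cc1`; the compounds differ only in the aryl group on one amide-type nitrogen. In a functional assay on A549 cells (Homo sapiens) for inhibition, read by CCK-8 assay, with a stated time of 72 h, tested at 1 uM (on this read-out higher numbers stand for more inhibition of growth at the one concentration tested and lower numbers for less inhibition of growth), compound 1 gives 1.1%, compound 2 gives 20.2% and compound 3 gives 77.1%. Compound 2 thus stands second highest of the three: a number 19.1 percentage points higher from compound 1 to compound 2 (beyond the scatter), while a number 56.9 percentage points higher from compound 2 to compound 3 (beyond the scatter), and a number 76 percentage points higher from compound 1 to compound 3 (beyond the scatter).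

Compound 4 `COc1cccc(NC(=O)C2(C(=O)Nc3ccc(Nc4ncc5cc(C(=O)N(C)C)n(C6CCCC6)c5n4)cc3)CC2)c1` is not yet measured. Relative to compound 2 the change is methoxy in place of bromo on an aromatic carbon, that is, 3-bromophenyl to 3-methoxyphenyl on the amide-type nitrogen. For the measured compounds named here, no measured step changes a group at this position alone; the two steps that bear on the amide aryl group, from compound 1 to compound 2 and from compound 2 to compound 3, show that swaps on this aryl group move this assay well beyond the scatter, in both modest and large size, and in both cases upward.

For compound 4 a modest rise is therefore expected, a number 11.8 percentage points higher from compound 2 to compound 4 (beyond the scatter), with wide uncertainty. Compound 4 is estimated at 32% in this assay, within a range of 5% to 65%.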

Compound 4, percent growth inhibition at one concentration: 77.2%
Estimate against measurement, compound 4: 45.2 percentage points below, and the stated range ends below it.
By their numbers in this assay, from the lowest: compound 1; then compound 2; then compounds 3 and 4 (each within the scatter of the next).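

In this assay, the exchange of a single group on the aryl ring, methoxy in place of bromo on an aromatic carbon, meta to a large group, carries a large step on its own: a number 57 percentage points higher from compound 2 to compound 4 (beyond the scatter). The substituent at this one place therefore decides much of the read-out, and two differently substituted aryl groups can reach the same level, with a number 0.1 percentage points higher from compound 3 to compound 4 (within the scatter), while the distance to the 4-chloro-3-(trifluoromethyl)phenyl group is large, with a number 76.1 percentage points higher from compound 1 to compound 4 (beyond the scatter). No measured property of these compounds bears on the result, and the data offer no account of it.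

Open, on these data alone, is whether the level depends on methoxy itself or on the absence of bromo, which an unsubstituted phenyl, a 3-hydroxyphenyl or a 3-aminophenyl group would test. Open too, as far as these compounds go, is whether a longer chain such as 3-ethoxyphenyl keeps the level, and whether compound 3 and compound 4 stay inseparable at other concentrations.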